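Removing the Bromo Group from the Shared Core of Compound 1

The source may hold more compounds than are shown below. What is called first, only, known or untested is meant among the compounds shown, and "the series" means these compounds.

Measured in a functional assay on MDA-MB-468 cells (Homo sapiens) for cytotoxicity, read by sulforhodamine B assay, with a stated time of 48 h; on this read-out lower numbers stand for stronger inhibition of growth and higher numbers for weaker inhibition of growth:
compound 1 `CN(C)CN1C(=O)C(=O)c2c(Br)cccc21`: 49000 nM
compound 2 `O=C1C(=O)N(CN2CCCCC2)c2cccc(Br)c21`: 35300 nM
compound 3 `CCN(CC)CN1C(=O)C(=O)c2c(Br)cccc21`: 11700 nM

Compound 1 gives the highest number of the three, meaning the weakest growth inhibition in the set. The change to compound 2 amounts to a 1.4-fold lower number from compound 1 to compound 2 (0.14 log units; within the scatter), which cannot be separated from repeat-to-repeat noise. The change to compound 3 is a 4.2-fold lower number from compound 1 to compound 3 (0.62 log units; beyond the scatter), a modest but real gain, and the step of a 3.0-fold lower number from compound 2 to compound 3 (0.48 log units; beyond the scatter) points the same way.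

Compound 4 `CN(C)CN1C(=O)C(=O)c2ccccc21` differs from compound 1 in one place: hydrogen in place of bromo on an aromatic carbon. All three measured steps concern only the amine on the saturated chain carbon, so none of them bears on the aromatic ring of the shared core. Among the compounds with values here, there is therefore no measured step to lean on, and the expectation is simply that compound 4 stays close to compound 1 in this assay, with no step beyond the scatter assumed. Compound 4 is estimated at 60000 nM, within a range of 20000 nM to 180000 nM, which means an expected step of a 1.2-fold higher number from compound 1 to compound 4 (0.09 log units; within the scatter).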

Compound 4, concentration for 50% growth inhibition: 50200 nM
Compound 4: the middle estimate sits 1.2-fold (0.08 log units) above what was measured, within the range that was stated.
By their numbers in this assay, from the lowest: compound 3; then compounds 2, 1 and 4 (each within the scatter of the next).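

In this assay, hydrogen in place of bromo on this aromatic carbon gives a 1.0-fold higher number from compound 1 to compound 4 (0.01 log units; within the scatter) and so leaves the growth-inhibition number of the dimethylamino compound unchanged within the scatter. The earlier compounds shown here differed only in the amine on the saturated chain carbon, whereas this step shows that, with dimethylamino on that chain, the bromo group can be lost from the aromatic ring of the shared core without a detectable change. No measurement here offers an explanation for this flat result.

Going by these compounds, it remains open whether a different group on this aromatic carbon, such as methoxy or an amine, would shift the number. On these data alone, it is also open whether losing the bromo group would be equally silent in compound 3, which carries diethylamino.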